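Benzyl Ester in Place of Ethyl: Expected Cell Effect

This account rests on a few compounds, and the source may have more. Where it says the series, first, only, none or still open, it means among the compounds named here.

Compound 1 `CCOC(=O)/C=C\NC(=O)[C@H](O)C(C)(C)CO` and compound 2 `CCOC(=O)/C=C/NC(=O)[C@@H](O)C(C)(C)CO` share one core and differ only in configuration as drawn. In an ADME assay on HEK293 cells (Homo sapiens) for inhibition, read by CellTiter-Glo, with a stated time of 96 h, tested at 100 uM (a lower number here means less inhibition, a higher number more inhibition at the concentration tested (going by the name of the read-out)), compound 1 gives -6%, and compound 2 gives -9%; the step of a number 3 percentage points lower from compound 1 to compound 2 (within the scatter) is small, and the only point to note is the fact that compounds 1 and 2 differ only in the configuration as drawn. Compound 2 thus holds the lower of the two numbers, though within the scatter of compound 1. Compound 3 `COC(=O)/C=C\NC(=O)[C@H](O)C(C)(C)CO` has in this assay the entry "not determined" (no result reported), so no number is available for it. Compound 4 `CC(C)(CO)[C@H](O)C(=O)N/C=C/C(=O)OCc1ccccc1` changes compound 2 by phenyl in place of methyl on a saturated chain carbon bound to an oxygen next to a carbonyl group. Going by the values given here, no measured step touches this change, since the single step concerns configuration only. Compound 4 is therefore expected to show about -4%, between -22% and 16%. The expected step of a number 5 percentage points higher from compound 2 to compound 4 (within the scatter) lies within the scatter.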

Compound 4, a percentage reported as inhibition, at one concentration (the size of the read-out at that concentration, not a potency): -6%
Compound 4: the middle estimate sits 2 percentage points above what was measured; low and high end bracket the measured number.
By their numbers in this assay, from the lowest: compounds 2, 1 and 4 (each within the scatter of the next).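

Going by these compounds alone, the only earlier step concerned configuration, so this is the first step that replaces one group with another: ethyl to benzyl, on a saturated chain carbon bound to an oxygen next to a carbonyl group, gives a number 3 percentage points higher from compound 2 to compound 4 (within the scatter). In this assay, adding a six-membered aromatic ring at this place thus leaves compound 4 within the scatter of compound 2. Nothing known here points to a cause for this result.

On these data alone, whether an amine, a carboxylic acid or a longer chain at this place would give a similar number remains open. So does whether benzyl would behave the same way with the Z double bond of compound 1.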